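The source may hold more compounds than are shown below. What is called first, only, known or untested is meant among the compounds shown, and "the series" means these compounds.

In an ADME assay on HaCaT cells (Homo sapiens) for inhibition, read by sulforhodamine B assay, with a stated time of 48 h (on this read-out higher numbers stand for weaker inhibition of growth and lower numbers for stronger inhibition of growth), compound 3 `CC(C)(C)NCc1c(C(=O)O)nn(-c2ccc(Cl)cc2)c1-c1ccccc1` gives 175000 nM, the higher of the two exact numbers available. The other exact number comes from compound 2 `CC(C)(C)NCc1c(C(=O)O)nn(-c2ccc(Cl)cc2)c1-c1ccc(F)cc1`, which gives 28700 nM. Compound 1 `COc1ccc(-c2c(CNC(C)(C)C)c(C(=O)O)nn2-c2ccccc2)cc1`, which carries a 4-methoxyphenyl group, gives > 659000 nM, and this is a limit of the assay and not a number.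

The next compound to consider is compound 4 `COc1ccc(-c2c(CNC(C)(C)C)c(C(=O)O)nn2-c2ccc(Cl)cc2)cc1`. It is compound 3 with methoxy in place of hydrogen on an aromatic carbon, turning phenyl into 4-methoxyphenyl (methoxy in place of hydrogen on an aromatic carbon). Within the data shown here, only one measured step changes a single group on this same phenyl ring: a 6.1-fold higher number from compound 2 to compound 3 (0.79 log units; beyond the scatter). That step, with hydrogen in place of fluoro, is modest but beyond the scatter. It shows that a change at this place can move the number, but it involves a different group and so cannot fix the direction for methoxy. Compound 1 gives no exact number to set against it, so it offers only weak guidance. The evidence therefore does not support a confident shift in either direction, and no change beyond the scatter is expected. The expected change is a 1.5-fold lower number from compound 3 to compound 4 (0.16 log units; within the scatter). Compound 4 is estimated at 120000 nM, with an expected range from 30000 nM to 450000 nM.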

Compound 4, concentration for 50% growth inhibition: 121000 nM
Compound 4: middle estimate off by 1.0-fold (0.00 log units), on the low side; the range from low to high includes it.
By their numbers in this assay, from the lowest: compound 2; then compounds 4 and 3 (each within the scatter of the next). At a limit, above all of these: compound 1.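

In this assay, methoxy and hydrogen at this place on the ring cannot be told apart, with a 1.4-fold lower number from compound 3 to compound 4 (0.16 log units; within the scatter), while fluoro separates from methoxy, with a 4.2-fold higher number from compound 2 to compound 4 (0.62 log units; beyond the scatter), so among the three groups seen here, fluoro alone stands apart, and putting a larger group in place of hydrogen does not by itself move the number. Compound 4 also forms a new pair that keeps the 4-methoxyphenyl group and changes only chloro in place of hydrogen on an aromatic carbon, giving an at least 5.4-fold lower number from compound 1 to compound 4 (0.73 log units; beyond the scatter), so with this group in place, chloro goes with a lower number. Compound 1 stands at a limit of the assay and not at a number, so that step gives only the smallest size it can have: the limit of > 659000 nM in this assay, at which 1 of the 4 values shown sits.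

Still open, on these data alone, is whether the lower number belongs to fluoro alone or would also appear with chloro, a hydroxyl group or an amine at this place on the ring. All the compounds shown keep the carboxylic acid on the shared core, so the effect of an ester there also remains unknown.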